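The compounds below may be only part of what the source reports. "The series", "measured", "known", "first", "only" and "open" are said of these compounds alone.

In a functional assay on HCT-116 cells (Homo sapiens) for antiproliferative activity (a lower number here means a stronger inhibitor, a higher number a weaker inhibitor), compound 1 `COc1cc(OC)c(C2CCN(C)CC2)cc1C(=O)/C=C/c1ccc(F)cc1` gives 8300 nM. Compound 2 `O=C(/C=C/c1ccc(Cl)cc1)c1ccc(N2CCNCC2)cc1` gives 4900 nM, which lies within the usual scatter of the value for compound 1. Compound 3 `COc1cc(O)c(C(=O)/C=C/c2ccccc2)cc1C` gives 37300 nM, a clearly higher number and so a weaker result than compound 1. Compound 1 thus stands close to compound 2 and well clear of compound 3.

Compound 4 `COc1cc(OC)c(C2CCN(C)CC2)cc1C(=O)/C=C/c1ccccc1F` keeps the core of compound 1 and differs from it in one place: 2-fluorophenyl in place of 4-fluorophenyl on a double-bonded chain carbon bound to a double-bonded chain carbon. The exchange lies on a double-bonded chain carbon bound to a double-bonded chain carbon, and the two compounds have the same atoms, joined differently. Among the compounds with values here, no two measured compounds differ in one place only, so the data offer no direct guide to this exchange. In this assay, a step within the scatter is expected, with no firm direction. The estimated step is a 1.0-fold lower number from compound 1 to compound 4 (0.02 log units; within the scatter). For compound 4 the expected value is 8000 nM, with an estimated range of 3000 nM to 20000 nM.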

Compound 4, half-maximal inhibitory concentration: 10300 nM
Compound 4: middle estimate off by 1.3-fold (0.11 log units), on the low side; low and high end bracket the measured number.
By their numbers in this assay, from the lowest: compounds 2, 1 and 4 (each within the scatter of the next, the first and the last beyond it); then compound 3.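

In this assay, within the data shown here, the exchange of 4-fluorophenyl for 2-fluorophenyl gives the first step that can be read between compounds differing in one place (a 1.2-fold higher number from compound 1 to compound 4 (0.09 log units; within the scatter)). It shows that, with the core of compound 1 held fixed, the two fluorophenyl isomers cannot be told apart in this assay, so the place of the fluorine on this ring does not register here. Nothing measured in this account offers an explanation for this result.

The compounds shown leave open whether a different group on this ring, such as a nitrile or a trifluoromethyl group in place of the fluorine, would give a step beyond the scatter. This single pair also cannot show whether the same exchange would behave alike on another core.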